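From 3-chlorophenyl to 4-(methylsulfanyl)phenyl on the shared core

The source may report more compounds than this note shows. Statements on the series, on what has been measured and on what is new or still open speak of the compounds shown alone.

Of the compounds shown here, two on the shared core have been measured so far: compound 1 (`COc1cc(-n2ncnc2-c2ccc(OC(F)(F)F)cc2)cc(OC)c1OC`) and compound 2 (`COc1cc(-n2ncnc2-c2cccc(Cl)c2)cc(OC)c1OC`). In a functional assay on K562 cells (Homo sapiens) for antiproliferative activity, read by MTT assay, with a stated time of 72 h (a lower number here means a stronger inhibitor, a higher number a weaker inhibitor), compound 1 gives > 10000 nM, which is a limit of the assay and not a number. In this assay compound 2 gives > 10000 nM, which is also a limit. The record so far is the limit of > 10000 nM in this assay, at which 2 of the 2 values shown sit. Among the measured compounds shown here, the series therefore has no numerical value yet, and no measured step is available to size the next change.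

Compound 3 (`COc1cc(-n2ncnc2-c2ccc(SC)cc2)cc(OC)c1OC`) carries 4-(methylsulfanyl)phenyl in place of 3-chlorophenyl on an aromatic carbon, (4-(methylsulfanyl)phenyl in place of 3-chlorophenyl on an aromatic carbon). With compound 2 at the limit of > 10000 nM, any measurable value for compound 3 would lie on the stronger side, so that is the expected direction in this assay. The expected change is an at least 5.0-fold lower number from compound 2 to compound 3 (0.69 log units; beyond the scatter), a modest estimated gain, and another result reported only as a limit remains quite possible. Compound 3 is expected at 2000 nM, with an estimated range of 100 nM to 10000 nM.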

Compound 3, half-maximal inhibitory concentration: 340 nM
Beside the measured number, compound 3's estimate is 5.9-fold (0.77 log units) above it; the range from low to high includes it.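

In this assay this position on the shared core, an aromatic carbon between two ring nitrogen atoms, can now be seen to respond to the aryl group it carries, as 4-(methylsulfanyl)phenyl in place of 3-chlorophenyl gives an at least 29-fold lower number from compound 2 to compound 3 (1.46 log units; beyond the scatter). Methylsulfanyl in place of trifluoromethoxy gives an at least 29-fold lower number from compound 1 to compound 3 (1.46 log units; beyond the scatter), so with a phenyl ring present in all three compounds, the ring alone is not enough for a measurable value, and what it carries decides the outcome here. Both steps start from a limit of the assay and not from a number, so each gives only a minimum size: the limit of > 10000 nM in this assay, at which 2 of the 3 values shown sit.

The step from 3-chlorophenyl changes both the substituent and its place on the phenyl ring, so the compounds shown do not separate these two contributions, and 3-(methylsulfanyl)phenyl would be the direct test. Going by these compounds, it also stays open whether the sulfur atom matters or whether a methoxy group, a longer ethylsulfanyl chain or a dimethylamino group would serve equally well at the same place.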